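Fluoro in place of methoxy on a thioether side arm

This account rests on a few compounds, and the source may have more. Where it says the series, first, only, none or still open, it means among the compounds named here.

Compound 1 `Nc1cc(N)c2nc(-c3ccccc3)c(NCc3ccc(Cl)c(Cl)c3)nc2c1`: 9770 nM
Compound 2 `COc1ccc(Sc2nc3cc(N)cc(N)c3nc2-c2ccccc2)cc1`: < 100000 nM

In a functional assay on SW-620 cells (Homo sapiens) for inhibition, read by sulforhodamine B assay, with a stated time of 48 h (a higher number here means a weaker inhibitor of growth, a lower number a stronger inhibitor of growth), compound 1 gives 9770 nM. For compound 2 only a limit is known: in this assay compound 2 is reported as < 100000 nM, a limit of the assay rather than a number, as the limit of < 100000 nM in this assay, at which 1 of the 2 values shown sits, shows. Compound 3 `Nc1cc(N)c2nc(-c3ccccc3)c(Sc3ccc(F)cc3)nc2c1` has not been measured; it differs from compound 2 by fluoro in place of methoxy on an aromatic carbon. No measured step of this kind exists among these compounds, so in this assay the change is expected to shift the result little, if at all beyond the scatter. Compound 3 is therefore expected at 30000 nM, between 5000 nM and 100000 nM. The estimated step is a step that the limit leaves unreadable from compound 2 to compound 3.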

Compound 3, concentration for total growth inhibition: 50100 nM
Beside the measured number, compound 3's estimate is 1.7-fold (0.22 log units) below it; the measured number falls inside the stated range.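

No step can be read between compound 2 and compound 3, because compound 2 carries only a limit of the assay: the limit of < 100000 nM in this assay, at which 1 of the 3 values shown sits.

The compounds shown leave open how far fluoro in place of methoxy on an aromatic carbon moves the result.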